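Trimming the acyl urea of compound 1 to an acrylamide

The source may hold more compounds than are shown below. What is called first, only, known or untested is meant among the compounds shown, and "the series" means these compounds.

The set comprises three measured compounds in a functional assay on MCF7 cells (Homo sapiens) for antiproliferative activity, with a stated time of 48 h; a lower number here means a stronger inhibitor, a higher number a weaker inhibitor. Compound 1 `CC(C)(C)c1ccc(CNC(=O)NC(=O)CCl)cc1` gives 2800 nM. Compound 3 `CC(C)(C)c1ccc(NC(=O)CCl)cc1` gives 5400 nM, and compound 2 `CCCCC(O)c1cccc(NC(=O)NC(=O)CCl)c1` gives 5700 nM. Of the three numbers, compound 1 has the lowest; the number for compound 3 sits within the usual scatter of it, whereas the number for compound 2 sits beyond that scatter. No two of these three compounds differ in only one place, so no single-change step can be read from them.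

The unmeasured compound 4 `C=CC(=O)NCc1ccc(C(C)(C)C)cc1` keeps the shared core of compound 1 and differs from it in one place: vinyl in place of ((chloromethyl)carbonyl)amino on a carbonyl carbon. This is a vinyl in place of ((chloromethyl)carbonyl)amino on a carbonyl carbon. Among the compounds with values here, nothing among the measured compounds shows the effect of this exchange, so the expectation rests only on the number for compound 1.

Compound 4 is estimated to give 6000 nM in this assay, with a range from 1500 nM to 25000 nM. This estimate means a step of a 2.1-fold higher number from compound 1 to compound 4 (0.33 log units; beyond the scatter) toward a higher number, of modest size, and a result within the scatter of compound 1 would not be surprising.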

Compound 4, half-maximal inhibitory concentration: > 100000 nM
Compound 4: no number, only a limit; the forecaster's own chance of this, stated with the estimate: 20%; at least 16-fold (1.22 log units) between middle value and limit.
By their numbers in this assay, from the lowest: compounds 1, 3 and 2 (each within the scatter of the next, the first and the last beyond it). At a limit, above all of these: compound 4.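

On a carbonyl carbon whose other neighbour is an amide-type nitrogen, putting vinyl in place of ((chloromethyl)carbonyl)amino brings an at least 35-fold higher number from compound 1 to compound 4 (1.55 log units; beyond the scatter), so this place proves far less forgiving of this change than a modest step would have implied. In this assay compound 4 gives > 100000 nM, which is a limit of the assay and not a number. The true size of the step stays open on its upper side because the reading sits at that limit: the limit of > 100000 nM in this assay, at which 1 of the 4 values shown sits.

The exchange removes the urea nitrogen, the second carbonyl and the chloromethyl group together and brings in vinyl, so the compounds shown leave open which of these parts accounts for the loss. A methyl or a bromomethyl group in place of the chloromethyl group, with the rest of the acyl urea kept, would begin to separate these parts, and a simple chloroacetamide on the same benzyl-bearing core would test the urea nitrogen and second carbonyl on their own.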